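The source may report more compounds than this note shows. Statements on the series, on what has been measured and on what is new or still open speak of the compounds shown alone.

In a functional assay on NCI-H460 cells (Homo sapiens) for antiproliferative activity, read by MTT assay, with a stated time of 48 h (on this read-out higher numbers stand for weaker inhibition and lower numbers for stronger inhibition), compound 3 `COc1cc(-c2cccc3nc(-c4ccc(Br)cc4)oc23)cc(OC)c1OC` reads > 25000 nM, which is a limit of the assay and not a number. Compound 1 `COc1cc(-c2cccc3nc(-c4ccccc4)oc23)cc(OC)c1OC` gives 6800 nM, and compound 2 `COc1ccc(-c2nc3cccc(-c4cc(OC)c(OC)c(OC)c4)c3o2)cc1F` gives 2800 nM. Compound 4 `COc1cc(-c2cccc3nc(-c4ccc(N)cc4)oc23)cc(OC)c1OC` carries amino in place of bromo on an aromatic carbon, para to a large group: amino in place of bromo on an aromatic carbon. Within the data shown here, two measured steps bear on this change: an at least 3.6-fold higher number from compound 1 to compound 3 (0.56 log units; beyond the scatter), on adding the bromo, and an at least 8.9-fold higher number from compound 2 to compound 3 (0.95 log units; beyond the scatter), on exchanging the whole ring substituent. The step of a 2.4-fold lower number from compound 1 to compound 2 (0.39 log units; beyond the scatter) shows that a substituted ring can also read lower than compound 1. Among the measured compounds shown here, no amino compound has been measured, so a moderate drop in this assay is expected, with an estimated at least 6.2-fold lower number from compound 3 to compound 4 (0.79 log units; beyond the scatter). For compound 4 the expected value is 4000 nM, with an estimated range of 800 nM to 18000 nM.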

Compound 4, half-maximal inhibitory concentration: 310 nM
Beside the measured number, compound 4's estimate is 13-fold (1.11 log units) above it; measured number below the stated range.
By their numbers in this assay, from the lowest: compound 4; then compound 2; then compound 1. At a limit, above all of these: compound 3.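

Amino in place of hydrogen gives a 22-fold lower number from compound 1 to compound 4 (1.34 log units; beyond the scatter), and amino in place of bromo gives an at least 80-fold lower number from compound 3 to compound 4 (1.90 log units; beyond the scatter), so a single atom at this place, para to a large group, can move the number strongly in either direction. The 4-aminophenyl group also reads lower than 3-fluoro-4-methoxyphenyl, with a 9.0-fold lower number from compound 2 to compound 4 (0.96 log units; beyond the scatter). The step from compound 3 starts from a limit and not a number: the limit of > 25000 nM in this assay, at which 1 of the 4 values shown sits.

The compounds shown leave open whether a methylamino, dimethylamino, hydroxyl or acetamide group at this place would read as low as amino. They also leave open whether amino elsewhere on this ring would do the same.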